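The source may report more compounds than this note shows. Statements on the series, on what has been measured and on what is new or still open speak of the compounds shown alone.

Measured in a functional assay on MCF7 cells (Homo sapiens) for cytotoxicity, read by MTT assay, with a stated time of 72 h; a higher number here means a weaker inhibitor of growth, a lower number a stronger inhibitor of growth:
- compound 1 `C=CCOC(=O)Nc1ccc([Se]C#N)cc1` gives 15000 nM
- compound 2 `CCCCOC(=O)Nc1ccc([Se][Se]c2ccc(NC(=O)OCCCC)cc2)cc1` gives 17300 nM
- compound 3 `CCOC(=O)Nc1ccc([Se][Se]c2ccc(NC(=O)OCC)cc2)cc1` gives 9900 nM

Compound 1 holds the second highest of the three numbers in this assay; the gap to compound 2 and the gap to compound 3 both fall within the usual scatter, so no order among the three can be read from these values.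

Compound 4 `CC(C)COC(=O)Nc1ccc([Se]C#N)cc1` is not yet measured. It differs from compound 1 in one place: isopropyl in place of vinyl on a saturated chain carbon bound to an oxygen next to a carbonyl group. Cut one bond further out, the change reads allyl to isobutyl. Going by the values given here, no measured pair in this set shows what such a change does in this assay.

The step from compound 1 to compound 4 is expected to stay within the scatter, with no clear direction: a 1.1-fold lower number from compound 1 to compound 4 (0.03 log units; within the scatter). For compound 4 in this assay the estimate is 14000 nM, within a range from 6000 nM to 32000 nM.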

Compound 4, concentration for 50% growth inhibition: 18100 nM
Estimate against measurement, compound 4: 1.3-fold (0.11 log units) below; low and high end bracket the measured number.
By their numbers in this assay, from the lowest: compounds 3, 1, 2 and 4 (each within the scatter of the next).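

In this assay, going by these compounds alone, isopropyl in place of vinyl on a saturated chain carbon bound to an oxygen next to a carbonyl group gives a 1.2-fold higher number from compound 1 to compound 4 (0.08 log units; within the scatter), the first direct reading of this position. Allyl and isobutyl cannot be told apart here, so neither the loss of the double bond nor the extra carbon has a readable effect on growth inhibition. No measured evidence bears on this result.

Still open, from the compounds shown here alone, is whether a different kind of group at this position, such as an amine or a carboxylic acid, would give a step beyond the scatter.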